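Removing a Methyl from the Pyridine Ring of Thiosemicarbazones

This account rests on a few compounds, and the source may have more. Where it says the series, first, only, none or still open, it means among the compounds named here.

Three compounds sharing a thiosemicarbazone link to a pyridine-bearing amidine have been tested in a functional assay on MCF7 cells (Homo sapiens) for cytotoxicity, read by MTT assay, with a stated time of 72 h, tested at 10 uM; a lower number here means less inhibition of growth, a higher number more inhibition of growth at the concentration tested. Compound 1, `Cc1ccnc(/C(N)=N/NC(=S)N2CCN(c3ccccn3)CC2)c1`, gives 32.1% in this assay. Compound 2, `Cc1cccc(/C(N)=N/NC(=S)N2CCCC2)n1`, gives 38.2%, and compound 3, `N/C(=N\NC(=S)N1CCCC1)c1ccccn1`, gives 51.7%. Compound 1 holds the lowest of the three numbers, but its gap to compound 2 lies within the scatter of the method, so no order between those two can be claimed; only its gap to compound 3 lies beyond the scatter. How the cores of compound 1 and compound 2 differ is not broken down here.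

For the measured compounds named here, the one step between measured compounds is hydrogen in place of methyl on an aromatic carbon, and it moved the read-out by a number 13.5 percentage points higher from compound 2 to compound 3 (beyond the scatter). Compound 4, `N/C(=N\NC(=S)N1CCN(c2ccccn2)CC1)c1ccccn1`, which is not yet measured, arises from compound 1 by hydrogen in place of methyl on an aromatic carbon. This is the same kind of change, though not the same: in the pair of compound 2 and compound 3 the methyl sits next to the ring nitrogen, while in compound 1 it sits opposite the ring nitrogen.

Going by the values given here, on that basis, compound 4 is expected to lie above compound 1 by about a number 10.9 percentage points higher from compound 1 to compound 4 (beyond the scatter) in this assay, resting on the step of a number 13.5 percentage points higher from compound 2 to compound 3 (beyond the scatter) as the only precedent, and the shifted place widens the uncertainty. The estimate for compound 4 is 43%, with a range from 30% to 56%.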

Compound 4, percent growth inhibition at one concentration: 46.4%
Beside the measured number, compound 4's estimate is 3.4 percentage points below it; low and high end bracket the measured number.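

In this assay, replacing the methyl opposite the ring nitrogen with hydrogen, which turns 4-methylpyridin-2-yl into pyridin-2-yl, gives a number 14.3 percentage points higher from compound 1 to compound 4 (beyond the scatter). The same kind of change had already raised the number on another core, and the two steps are alike in size, so in these two pairs the effect of removing a methyl carries from one core to the other: the same change on two cores in this assay, a number 13.5 percentage points higher (beyond the scatter) from compound 2 to compound 3 and a number 14.3 percentage points higher (beyond the scatter) from compound 1 to compound 4, 0.8 percentage points apart, within the scatter of two such steps

For the compounds shown here, this agreement rests on only two pairs, and the methyl does not occupy the same ring position in both, so it does not show that the step would keep its size on any further core, and it does not explain why removing the methyl raises the number.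

The compounds shown leave open what other groups at the place opposite the ring nitrogen would do, for example an ethyl, a methoxy or an amine, since methyl and hydrogen are the only two compared there. They also leave open whether the step would appear in growth inhibition on other cell lines or at other concentrations, since every number here comes from one cell line at one concentration.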